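Where a 4-Chlorobenzyl Ether May Lead Compound 1

This account rests on a few compounds, and the source may have more. Where it says the series, first, only, none or still open, it means among the compounds named here.

Compound 1 `COc1cc2c(c(O)c1OC)C(=O)[C@]1(OC)C=C[C@H]2N(C(=O)OCC(C)C)N1C(=O)OCC(C)C` carries a free hydroxy on its aromatic ring and two isobutyl carbamates. Within the data shown here, in an ADME assay on KB cells (Homo sapiens) for cytotoxicity (on this read-out higher numbers stand for an effect only at larger amounts of compound and lower numbers for an effect already at smaller amounts), compound 1 reaches only the limit of the measurement, > 300 ug/mL, and so gives no number; it is the single compound that stands at this edge (the limit of > 300 ug/mL in this assay, at which 1 of the 3 values shown sits). Two related benzyl ethers with smaller carbamates have been measured. Compound 2 `COC(=O)N1[C@@H]2C=C[C@@](OC)(C(=O)c3c2cc(OC)c(OC)c3OCc2ccc(F)cc2)N1C(=O)OC` gives 56.6 ug/mL in this assay, and compound 3 `CCOC(=O)N1[C@@H]2C=C[C@@](OC)(C(=O)c3c2cc(OC)c(OC)c3OCc2ccc(OC)cc2)N1C(=O)OCC` gives 63.1 ug/mL in this assay; these two values lie within the usual scatter of each other.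

Compound 4 `COc1cc2c(c(OCc3ccc(Cl)cc3)c1OC)C(=O)[C@]1(OC)C=C[C@H]2N(C(=O)OCC(C)C)N1C(=O)OCC(C)C` differs from compound 1 in one place: 4-chlorobenzyl in place of hydrogen on an oxygen on an aromatic ring. Among the measured compounds shown here, no step between two measured compounds follows this change, so any expectation rests on compound 2 with 56.6 ug/mL and on compound 3 with 63.1 ug/mL, both of which sit well inside the measured range. The step of an at least 6.6-fold lower number from compound 1 to compound 4 (0.82 log units; beyond the scatter) is therefore expected to run toward lower numbers and to exceed the scatter. Compound 4 is estimated at 45 ug/mL in this assay, within a range from 12 ug/mL to 160 ug/mL.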

Compound 4, concentration for half-maximal effect: 42 ug/mL
Beside the measured number, compound 4's estimate is 1.1-fold (0.03 log units) above it, and the stated range covers the measured number.
By their numbers in this assay, from the lowest: compounds 4, 2 and 3 (each within the scatter of the next). At a limit, above all of these: compound 1.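

In this assay, the change of 4-chlorobenzyl in place of hydrogen on an oxygen on an aromatic ring gives a directly measured step: an at least 7.1-fold lower number from compound 1 to compound 4 (0.85 log units; beyond the scatter). The earlier benzyl ethers, compound 2 and compound 3, differ from compound 1 in more than one place, whereas this pair keeps both isobutyl carbamates and so ties the step to this oxygen alone. The true size of the step remains unknown, because the value for compound 1 is a limit and not a number: the limit of > 300 ug/mL in this assay, at which 1 of the 4 values shown sits.

On these data alone, whether a plain methyl, an unsubstituted benzyl or a longer alkyl chain on this oxygen would give a similar step remains open. So does the question of whether the chlorine contributes anything, or whether the step depends on the aromatic ring of the new group.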